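The source may hold more compounds than are shown below. What is called first, only, known or untested is meant among the compounds shown, and "the series" means these compounds.

Compound 2 `Nc1cc(N)c2nc(-c3ccccc3)c(NCc3ccc(F)cc3)nc2c1` in a functional assay on MDA-MB-435 cells (Homo sapiens) for inhibition, read by sulforhodamine B assay, with a stated time of 48 h (on this read-out higher numbers stand for lower toxicity in this test and lower numbers for higher toxicity in this test), gives 6920 nM; compound 1 `COc1ccc(CNc2nc3cc(N)cc(N)c3nc2-c2ccccc2)cc1OC` gives 8510 nM, and the two numbers lie within the scatter of each other, so neither stands apart. Going by the values given here, the single measured step, a 1.2-fold lower number from compound 1 to compound 2 (0.09 log units; within the scatter), exchanged one substituted benzyl group for another without moving the read-out beyond the scatter. Compound 3 `COc1ccc(CNc2nc3cc(N)cc(N)c3nc2-c2ccccc2)cc1` differs from compound 2 by methoxy in place of fluoro on an aromatic carbon. Among the compounds with values here, the step from compound 1 to compound 2 is the only one bearing on this change, and it stayed within the scatter. For compound 3 the expected step in this assay is therefore a 1.1-fold higher number from compound 2 to compound 3 (0.03 log units; within the scatter), nothing beyond the scatter. Compound 3 is estimated at 7500 nM, within 3500 nM to 16000 nM.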

Compound 3, concentration lethal to 50% of the cells: 46800 nM
For compound 3 the middle estimate is 6.2-fold (0.80 log units) below the measured one; measured number above the stated range.
By their numbers in this assay, from the lowest: compounds 2 and 1 (each within the scatter of the next); then compound 3.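

In this assay this place on the benzyl group is not silent: methoxy in place of fluoro, para to a large group, gives a 6.8-fold higher number from compound 2 to compound 3 (0.83 log units; beyond the scatter), towards lower toxicity in this test. Hydrogen in place of methoxy gives a 5.5-fold higher number from compound 1 to compound 3 (0.74 log units; beyond the scatter), so compound 3 stands apart from both neighbours, although compound 1 and compound 2 lie within the scatter of each other. No measurement here accounts for this. Open, from the compounds shown here alone, is whether the high number belongs to the 4-methoxybenzyl group alone; a hydroxy or chloro group at this place, or an unsubstituted benzyl group, would test that.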